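The source may hold more compounds than are shown below. What is called first, only, known or untested is meant among the compounds shown, and "the series" means these compounds.

In a functional assay on PC-3 cells (Homo sapiens) for cytotoxicity, read by MTT assay, with a stated time of 72 h (on this read-out higher numbers stand for weaker inhibition and lower numbers for stronger inhibition), compound 1 `COc1cc2ncnc(Nc3ccc(F)c(Cl)c3)c2cc1NC(=O)N/N=C/c1ccc(F)cc1Cl` gives 25700 nM and compound 2 `COc1cc2ncnc(Nc3ccc(F)c(Cl)c3)c2cc1NC(=O)N/N=C/c1cccc(Cl)c1Cl` gives 24400 nM, while compound 3 `COc1cc2ncnc(Nc3ccc(F)c(Cl)c3)c2cc1NC(=O)N/N=C/c1ccc(OC)c(OC)c1OC` gives 29300 nM on the same read-out. Compound 3 stands level with the other two, with a 1.1-fold higher number from compound 1 to compound 3 (0.06 log units; within the scatter) and a 1.2-fold higher number from compound 2 to compound 3 (0.08 log units; within the scatter) both inside the scatter.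

Compound 4 `COc1cc2ncnc(Nc3ccc(F)c(Cl)c3)c2cc1NC(=O)N/N=C/c1cc(OC)c(OC)c(OC)c1` carries 3,4,5-trimethoxyphenyl in place of 2,3,4-trimethoxyphenyl on a carbon with a double bond to nitrogen. The nearest evidence is the change of group at that same carbon, where a 1.1-fold lower number from compound 1 to compound 2 (0.02 log units; within the scatter) joins the two steps above and none leaves the scatter. Going by the values given here, no measured step only rearranges a trimethoxyphenyl group, so this evidence is indirect.

No step beyond the scatter is therefore expected in this assay and no direction is favoured. The estimated step is a 1.2-fold lower number from compound 3 to compound 4 (0.07 log units; within the scatter) and it is expected to stay within the scatter. For compound 4 the expected value is 25000 nM with 11000 nM to 48000 nM as its estimated range.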

Compound 4, half-maximal inhibitory concentration: 36500 nM
The estimate for compound 4 lay 1.5-fold (0.16 log units) below the measured number, within the range that was stated.
By their numbers in this assay, from the lowest: compounds 2, 1, 3 and 4 (each within the scatter of the next).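

In this assay, 3,4,5-trimethoxyphenyl in place of 2,3,4-trimethoxyphenyl on a carbon with a double bond to nitrogen gives a 1.2-fold higher number from compound 3 to compound 4 (0.10 log units; within the scatter), so a rearrangement of the same atoms stays inside the scatter, as the exchanges of group did. Going by these compounds alone, the same group in place of 2,3-dichlorophenyl gives a 1.5-fold higher number from compound 2 to compound 4 (0.17 log units; within the scatter), and in place of 2-chloro-4-fluorophenyl it gives a 1.4-fold higher number from compound 1 to compound 4 (0.15 log units; within the scatter); these are the largest steps so far, yet neither leaves the scatter, so all four substituted phenyl groups stand level at this place. No measurement on hand accounts for this flat picture.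

As far as these compounds go, whether a phenyl group carrying an amine or a carboxylic acid would leave the scatter stays open. Also open, from the compounds shown here alone, is how far a change elsewhere on the shared core would move the number.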